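The source may report more compounds than this note shows. Statements on the series, on what has been measured and on what is new or still open speak of the compounds shown alone.

Values in a functional assay on MCF7 cells (Homo sapiens), read by MTT assay, with a stated time of 48 h (on this read-out higher numbers stand for weaker inhibition and lower numbers for stronger inhibition), so far:
compound 1 `CCn1c(C(=O)N(CCC#N)CCC#N)ccc1C(CC)(CC)c1ccc(OCC(O)C(C)(C)C)c(C)c1` gives 480 nM
compound 2 `CC[C@@H](C)[C@H](NC(=O)c1ccc(C(CC)(CC)c2ccc(OCC(O)C(C)(C)C)c(C)c2)n1CC)C(=O)O` gives 2000 nM

Of these two, compound 2 stands highest at 2000 nM and so shows the weaker inhibition. Compound 3 `CCn1c(C(=O)Oc2ccc(CCO)cc2)ccc1C(CC)(CC)c1ccc(OCC(O)C(C)(C)C)c(C)c1` is still unmeasured. It differs from compound 2 by a group of 10 heavy atoms (8 carbon, 2 oxygen; one six-membered aromatic ring of carbon only) in place of a group of 9 heavy atoms (6 carbon, 1 nitrogen, 2 oxygen; no ring), on a carbonyl carbon on a carbonyl carbon, where the (1-carboxy-2-methylbutyl)amino group leaves and a group with one six-membered aromatic ring of carbon only enters. Among the compounds with values here, one measured step bears on this place, a 4.2-fold higher number from compound 1 to compound 2 (0.62 log units; beyond the scatter), a modest step beyond the scatter. Within the data shown here, no measured compound carries a ring in this group, so the evidence is thin. A modest step toward a lower number is therefore expected in this assay, smaller than or close to that one. The estimated step is a 2.0-fold lower number from compound 2 to compound 3 (0.30 log units; within the scatter), with wide uncertainty. For compound 3 the expected value is 1000 nM, with an estimated range of 300 nM to 3500 nM in this assay.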

Compound 3, half-maximal inhibitory concentration: > 50000 nM
Compound 3 gave a limit, no number (the forecaster's own chance of this, stated with the estimate: 5%); middle value at least 50-fold (1.69 log units) from the limit.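

In this assay compound 3 gives only a limit, not a number: > 50000 nM. The substituent on the carbonyl carbon can therefore move this read-out much further than the modest 4.2-fold higher number from compound 1 to compound 2 (0.62 log units; beyond the scatter) indicated, since the entering group with its six-membered aromatic ring gives an at least 25-fold higher number from compound 2 to compound 3 (1.39 log units; beyond the scatter) and an at least 100-fold higher number from compound 1 to compound 3 (2.01 log units; beyond the scatter). Both steps are large and beyond the scatter, but each is a minimum and the true size stays unresolved: the limit of > 50000 nM in this assay, at which 1 of the 3 values shown sits.

The entering group brings the ring and removes the nitrogen on the carbonyl carbon in a single change, so the two remain inseparable here; an anilide carrying the same ring would divide them. Also open, on these data alone, is how an amine or a carboxylic acid in place of the hydroxyl of the entering group would read.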